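This account rests on a few compounds, and the source may have more. Where it says the series, first, only, none or still open, it means among the compounds named here.

Compound 1 `CCNC(=O)c1cc(Oc2ccc(NC(=O)c3cc4cccnc4n(-c4ccccc4)c3=O)cc2)ccn1` is the reference point of this small set, and in a functional assay on NCI-H460 cells (Homo sapiens) for antiproliferative activity, read by MTT assay, with a stated time of 72 h (a lower number here means a stronger inhibitor, a higher number a weaker inhibitor), compound 1 gives 1120 nM. Two single changes to it have been measured. Compound 2 `CCNC(=O)c1cc(Oc2ccc(NC(=O)c3cc4cccnc4n(-c4ccc(F)cc4)c3=O)cc2)ccn1` differs from compound 1 by fluoro in place of hydrogen on an aromatic carbon, and with that change in this assay the number moves a 5.1-fold lower number from compound 1 to compound 2 (0.71 log units; beyond the scatter). Compound 3 `CCCNC(=O)c1cc(Oc2ccc(NC(=O)c3cc4cccnc4n(-c4ccccc4)c3=O)cc2)ccn1` differs from compound 1 by methyl in place of hydrogen on a saturated chain carbon, two bonds along the chain from an amide-type nitrogen, and in this assay compound 3 gives 110 nM, which is a 10-fold lower number from compound 1 to compound 3 (1.01 log units; beyond the scatter). In this assay compound 2 gives 220 nM, a number that lies within the usual scatter of that of compound 3, so the two are not ordered here.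

Compound 4 `CCCNC(=O)c1cc(Oc2ccc(NC(=O)c3cc4cccnc4n(-c4ccccc4F)c3=O)cc2)ccn1` has not yet been measured in this assay. It carries the core of compound 3 and differs from it by fluoro in place of hydrogen on an aromatic carbon. The difference between compound 1 and compound 2 is of the same kind, but not the same: there the fluoro stands para to a large group, whereas in compound 4 it stands ortho to a large group. For the measured compounds named here, because the one measured example of a fluoro entering on this ring, a 5.1-fold lower number from compound 1 to compound 2 (0.71 log units; beyond the scatter), is a step of modest size, and because compound 3 already stands at 110 nM, compound 4 is expected to move by a smaller step, estimated as a 1.4-fold lower number from compound 3 to compound 4 (0.14 log units; within the scatter). Going by the values given here, no other ortho example is available, so this expectation rests only on the para step. Compound 4 is therefore expected to give about 80 nM in this assay, estimated within the range from 25 nM to 300 nM.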

Compound 4, half-maximal inhibitory concentration: 390 nM
Beside the measured number, compound 4's estimate is 4.9-fold (0.69 log units) below it, and the stated range ends below it.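

In this assay the entry of fluoro gives a 3.5-fold higher number from compound 3 to compound 4 (0.55 log units; beyond the scatter), so in this series the change did not carry from the core of compound 1 to the core of compound 3 with its direction kept, and the two steps cannot be treated as one transferable effect: the same change on two cores in this assay, a 5.1-fold lower number (0.71 log units; beyond the scatter) from compound 1 to compound 2 and a 3.5-fold higher number (0.55 log units; beyond the scatter) from compound 3 to compound 4, 18-fold (1.26 log units) apart, beyond the scatter of two such steps.

This does not show what separates the two results, since the steps differ in two ways at once: compound 2 has an ethyl amide and compound 4 a propyl amide, and the fluoro of compound 4 stands ortho to a large group, whereas that of compound 2 stands elsewhere on the ring. For the compounds shown here, with only this one pair of steps, the part played by the amide chain cannot be told from the part played by the place of the fluoro, and no general rule for fluoro on this ring follows from them.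

The compounds shown leave open how a 2-fluorophenyl group would read on the core of compound 1, and how the fluoro of compound 2 would read on the core of compound 3, either of which would pull the two differences apart. They also leave open how chloro or methoxy on the same ring, or a butyl chain on the amide, would stand in this series.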